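Extending the benzylic amine in a melanocortin receptor 4 series

The source may hold more compounds than are shown below. What is called first, only, known or untested is meant among the compounds shown, and "the series" means these compounds.

Measured compounds:
compound 1, `CC[C@H](C)C(N)c1cc(C(F)(F)F)ccc1N1CCN(C(=O)CCc2ccc(Cl)cc2Cl)CC1`, 75 nM
compound 2, `CCC(C)[C@H](N)c1cc(C(F)(F)F)ccc1N1CCN(C(=O)CCc2ccc(Cl)cc2)CC1`, 86 nM
compound 3, `CC(C)C[C@H](N)c1cc(C(F)(F)F)ccc1N1CCN(C(=O)CCc2csc3ccccc23)CC1`, 2300 nM

The three measured compounds share one core and differ in the side chain on the amide and in the group on the aromatic carbon. In an assay on HEK293 cells for displacement of a labelled ligand from Melanocortin receptor 4 (Homo sapiens) (a higher number here means a weaker inhibitor, a lower number a stronger inhibitor), compound 1 gives 75 nM, the lowest of the three numbers; compound 2 sits within the scatter of it, while compound 3 lies well beyond the scatter on the weaker side. Among the measured compounds shown here, no single-point step between measured compounds exists, so the effect of changing the benzylic amine itself has not been observed.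

Compound 4, `CCC(C)[C@H](NC[C@H](C)N)c1cc(C(F)(F)F)ccc1N1CCN(C(=O)CCc2ccc(Cl)cc2Cl)CC1`, carries a single change from compound 1: 1-((2-aminopropyl)amino)-2-methylbutyl in place of 1-amino-2-methylbutyl on an aromatic carbon. The measured compounds give no direct guide to this kind of extension. The step from compound 1 to compound 4 in this assay is therefore expected to be small, if anything towards a lower number, and is estimated as a 1.7-fold lower number from compound 1 to compound 4 (0.22 log units; within the scatter). Compound 4 is expected to give about 45 nM, in a range from 10 nM to 200 nM.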

Compound 4, inhibition constant: 89 nM
For compound 4 the middle estimate is 2.0-fold (0.30 log units) below the measured one; low and high end bracket the measured number.
By their numbers in this assay, from the lowest: compounds 1, 2 and 4 (each within the scatter of the next); then compound 3.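

In this assay, 1-((2-aminopropyl)amino)-2-methylbutyl in place of 1-amino-2-methylbutyl on an aromatic carbon gives a 1.2-fold higher number from compound 1 to compound 4 (0.07 log units; within the scatter). Among the compounds shown here, this is the first single-place step, and it shows that the amine nitrogen of compound 1 can carry the 2-aminopropyl chain, with a second nitrogen in the group, while the binding number stays within the scatter of that of compound 1. No measured evidence is available to explain this result.

On these data alone, whether the second amine contributes at all stays open, and a plain propyl chain or a 2-hydroxypropyl chain on the same nitrogen would separate it from the added length. Also open, as far as these compounds go, is how a longer 3-aminopropyl chain, or the opposite configuration at the carbon bearing the new amine, would read in this assay.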